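This account rests on a few compounds, and the source may have more. Where it says the series, first, only, none or still open, it means among the compounds named here.

Measured so far in a functional assay on cells (Tumor Cell line, Homo sapiens) for cytotoxicity; a higher number here means a weaker inhibitor, a lower number a stronger inhibitor:
- compound 1 `CN(C)Cc1cc(C(=O)/C=C/c2cccc(Cl)c2)cc(CN(C)C)c1O`: 4680 nM
- compound 2 `CN(C)Cc1cc(C(=O)/C=C/c2c(F)cccc2Cl)cc(CN(C)C)c1O`: 9120 nM

For the measured compounds named here, compound 2, at 9120 nM, is not separated from compound 1, since the only measured step, a 1.9-fold higher number from compound 1 to compound 2 (0.29 log units; within the scatter), lies within the scatter. The two compounds therefore stand as one level in this assay.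

Next is compound 3 `CN(C)Cc1cc(C(=O)/C=C/c2ccc(O)cc2)cc(CN(C)C)c1O`, which keeps the shared core and changes the aryl group: 4-hydroxyphenyl in place of 2-chloro-6-fluorophenyl on a double-bonded chain carbon bound to a double-bonded chain carbon. Here 4-hydroxyphenyl comes in place of 2-chloro-6-fluorophenyl, on a double-bonded chain carbon bound to a double-bonded chain carbon.

Going by the values given here, only one measured step bears on this change. It falls at the same place, and a 1.9-fold higher number from compound 1 to compound 2 (0.29 log units; within the scatter) stays within the scatter. Among the compounds with values here, that step exchanges one halogen-bearing phenyl for another, and no compound carrying 4-hydroxyphenyl has been measured, so the guidance is thin. No shift beyond the scatter is expected in either direction, though the uncertainty is wide. The estimated step is a 1.4-fold lower number from compound 2 to compound 3 (0.15 log units; within the scatter). For compound 3 the expected value is 6500 nM, with an estimated range of 2200 nM to 19000 nM.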

Compound 3, half-maximal inhibitory concentration: 39800 nM
Estimate against measurement, compound 3: 6.1-fold (0.79 log units) below, and the stated range ends below it.
By their numbers in this assay, from the lowest: compounds 1 and 2 (each within the scatter of the next); then compound 3.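

At this place, on a double-bonded chain carbon bound to a double-bonded chain carbon, the aryl group can shift the number in this assay beyond the scatter: 4-hydroxyphenyl in place of 2-chloro-6-fluorophenyl gives a 4.4-fold higher number from compound 2 to compound 3 (0.64 log units; beyond the scatter), and 4-hydroxyphenyl in place of 3-chlorophenyl gives an 8.5-fold higher number from compound 1 to compound 3 (0.93 log units; beyond the scatter). The two chlorine-bearing aryl groups remain one level, while compound 3 is the weakest of the three, so this position is not indifferent to the aryl group and the change to 4-hydroxyphenyl goes in the direction of weaker inhibition. Nothing available here accounts for this shift.

The compounds shown leave open whether the shift follows from the entering hydroxyl group or from the departing chlorine, since compound 3 differs from compound 1 and compound 2 in both respects. Plain phenyl, 4-chlorophenyl and 4-methoxyphenyl at the same place would help separate these two readings, and the shared core would stay as it is in compound 3.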